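Removing Both Ring Substituents from the Urea of Compound 3

The source may hold more compounds than are shown below. What is called first, only, known or untested is meant among the compounds shown, and "the series" means these compounds.

Measured compounds:
- Compound 1, `O=C(O)CCNC(=O)c1ccc(CN(C(=O)Nc2cc(Cl)cc(Cl)c2)c2ccc(C3=CCCCC3)cc2)cc1`: 64 nM
- Compound 2, `O=C(NC[C@@H](O)C(=O)O)c1ccc(CN(C(=O)Nc2cc(Br)cc(C(F)(F)F)c2)c2ccc(C3=CCCCC3)cc2)cc1`: 380 nM
- Compound 3, `COc1cc(NC(=O)N(Cc2ccc(C(=O)NC[C@@H](O)C(=O)O)cc2)c2ccc(C3=CCCCC3)cc2)cc(C(F)(F)F)c1`: 279 nM

All three share a core in which a benzylated urea carries a 1-cyclohexenylphenyl group and an acid-bearing side chain, and differ mainly in the aromatic ring attached to the urea nitrogen. In an in vitro assay on BHK cells for binding affinity to gastric inhibitory polypeptide receptor (Homo sapiens) (on this read-out higher numbers stand for weaker inhibition and lower numbers for stronger inhibition), compound 3 gives 279 nM, the second highest of the three numbers. Its nearest neighbour is compound 2; the step of a 1.4-fold lower number from compound 2 to compound 3 (0.13 log units; within the scatter) is within the scatter. Compound 1 gives 64 nM, a lower number, but it differs from compound 3 in two places, so no single step can be read from that pair.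

Compound 4, `O=C(NC[C@@H](O)C(=O)O)c1ccc(CN(C(=O)Nc2ccccc2)c2ccc(C3=CCCCC3)cc2)cc1`, has not yet been measured in this assay. It differs from compound 3 as follows: phenyl in place of 3-methoxy-5-(trifluoromethyl)phenyl on an amide-type nitrogen. Among the measured compounds shown here, the only single-place step on this ring, from compound 2 to compound 3, swapped one substituent for another and changed little. Here both substituents are taken away at once, a larger change than that step covers, and no measured pair shows a ring without substituents. The expectation is therefore uncertain, leaning toward a higher number, that is weaker binding, with a wide range. The step of a 2.5-fold higher number from compound 3 to compound 4 (0.40 log units; beyond the scatter) is the estimated change. Compound 4 is estimated at 700 nM, with a range from 200 nM to 2500 nM.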

Compound 4, half-maximal inhibitory concentration: 1390 nM
For compound 4 the middle estimate is 2.0-fold (0.30 log units) below the measured one; the range from low to high includes it.
By their numbers in this assay, from the lowest: compound 1; then compounds 3 and 2 (each within the scatter of the next); then compound 4.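

In this assay, the bare phenyl ring gives a 5.0-fold higher number from compound 3 to compound 4 (0.70 log units; beyond the scatter) and, from the bromo partner, a 3.7-fold higher number from compound 2 to compound 4 (0.56 log units; beyond the scatter) as well, so both steps point to weaker binding and both lie beyond the scatter. The earlier pair showed only that methoxy and bromo could replace each other on this ring with no change beyond the scatter, while this result shows that the ring's substituents do matter: with both gone, the number rises clearly, so the position is tolerant of a swap but not of removal. Nothing available here explains this loss, so the size of the step stands as an observation without a known cause.

Both substituents left together, so the compounds shown cannot say whether the trifluoromethyl group, the methoxy or bromo group, or only the pair of them accounts for the change, and a ring keeping just one of them would separate these cases. On these data alone, it also remains open whether a quite different group at this place, such as a nitrile or an amine, would hold the binding seen with methoxy and bromo.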